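A few compounds are considered here, and "the series" means these few. Any claim that something is new, unique, unknown or untested is made for them only; others in the source may bear on it.

Measured compounds:
- compound 1, `O=C(O)c1ccc(C(=O)/C(=C\c2ccc(Cl)c([N+](=O)[O-])c2)SCc2ccc(Cl)cc2Cl)cc1`, in a physicochemical assay for solubility (a lower number here means a less soluble compound, a higher number a more soluble compound), gives < 1000 ug/mL
- compound 2, `O=C(O)c1ccc(C(=O)/C(=C\c2ccc(Br)c([N+](=O)[O-])c2)SCc2ccc(Cl)cc2)cc1`, in this assay gives < 1000 ug/mL

Both of these values are limits of this assay and not numbers. For compound 2 the value < 1000 ug/mL is a limit, so its solubility is known only as sitting at that bound. Among the compounds with values here, the same holds for compound 1, whose value < 1000 ug/mL is also a limit, and the two compounds therefore cannot be ordered against each other; the only evidence here is the limit of < 1000 ug/mL in this assay, at which 2 of the 2 values shown sit.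

Compound 3, `O=C(O)c1ccc(C(=O)/C(=C\c2ccc(Br)c([N+](=O)[O-])c2)SCc2ccc(Cl)cc2Cl)cc1`, has not been measured. It differs from compound 2 by chloro in place of hydrogen on an aromatic carbon. Within the data shown here, with both measured compounds resting at the limit, no measured step exists between them on which to rest an expectation for this change, and the size of the step from compound 2 to compound 3 is unknown; it is estimated to be small, a step that the limit leaves unreadable from compound 2 to compound 3, with no direction that can be told beyond the scatter. Compound 3 is expected to give about 300 ug/mL in this assay, within a range of 30 ug/mL to 1000 ug/mL, and most likely to be reported again only as a limit.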

Compound 3, solubility: < 1000 ug/mL
Compound 3 was reported as a limit (the forecaster's own chance of this, stated with the estimate: 85%); the middle value lies beyond the limit too.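

In this assay compound 3 gives < 1000 ug/mL, which is a limit and not a number. Within the data shown here, no step from compound 1 or compound 2 to compound 3 can be read. The compounds shown leave open the actual values of all three, and whether chloro in place of hydrogen or bromo in place of chloro on an aromatic carbon shifts the result in this assay at all: the limit of < 1000 ug/mL in this assay, at which 3 of the 3 values shown sit.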